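The source may hold more compounds than are shown below. What is called first, only, known or untested is meant among the compounds shown, and "the series" means these compounds.

In a physicochemical assay for solubility, in phosphate buffer, at pH 7.4 (on this read-out lower numbers stand for lower solubility and higher numbers for higher solubility), compound 1 `OCC1CCN(c2nccnc2OC2CN(c3ccc4ccccc4n3)C2)C1` gives 167000 nM, and compound 2 `N#CC1CCN(c2nccnc2OC2CN(c3ccc4ccccc4n3)C2)CC1` gives 66000 nM. Compound 3 `N#Cc1ccc(-c2nccnc2OC2CN(c3ccc4ccccc4n3)C2)cc1` gives < 1000 nM, which is a limit of the assay and not a number. The structural change 1,3-benzothiazol-5-yl in place of 4-cyanophenyl on an aromatic carbon leads to compound 4 `c1ccc2nc(N3CC(Oc4nccnc4-c4ccc5scnc5c4)C3)ccc2c1`, with 1,3-benzothiazol-5-yl in place of 4-cyanophenyl on an aromatic carbon. Within the data shown here, no measured step exchanges one aromatic group for another, so the evidence is indirect. Replacing 3-(hydroxymethyl)pyrrolidin-1-yl with 4-cyanopiperidin-1-yl gave only a 2.5-fold lower number from compound 1 to compound 2 (0.40 log units; beyond the scatter). Bringing in 4-cyanophenyl gave much larger drops, with an at least 160-fold lower number from compound 1 to compound 3 (2.22 log units; beyond the scatter) and an at least 66-fold lower number from compound 2 to compound 3 (1.81 log units; beyond the scatter). Compound 4 still carries an aromatic group on that carbon, so it is expected to resemble compound 3 rather than compound 1 or compound 2, with no step beyond the scatter. The expected change is a step that the limit leaves unreadable from compound 3 to compound 4. For compound 4 the estimated value is 600 nM, with an expected range from 150 nM to 2000 nM.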

Compound 4, solubility: < 1000 nM
Compound 4: a limit, no number (the forecaster's own chance of this, stated with the estimate: 75%); the middle value does not contradict the limit.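

In this assay compound 4 gives < 1000 nM, which is a limit of the assay and not a number. With 1,3-benzothiazol-5-yl on this aromatic carbon, a group that carries no nitrile, the piece shows an at least 66-fold lower number from compound 2 to compound 4 (1.81 log units; beyond the scatter) and an at least 160-fold lower number from compound 1 to compound 4 (2.22 log units; beyond the scatter), so the large drop seen earlier is not confined to 4-cyanophenyl and appears with both aromatic groups shown at this position. The step between the two aromatic groups cannot be read, and neither group can be placed above the other: the limit of < 1000 nM in this assay, at which 2 of the 4 values shown sit.

The compounds shown leave open how far the true values of compound 3 and compound 4 lie beyond this limit. They also leave open whether an aromatic group carrying an amine or a carboxylic acid on this carbon would stay at the limit or rise clear of it.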